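Benzyl for tert-butoxycarbonyl on the ring nitrogen: solubility outlook

A few compounds are considered here, and "the series" means these few. Any claim that something is new, unique, unknown or untested is made for them only; others in the source may bear on it.

Compound 1 `CC(C)(C)OC(=O)N1CCC[C@H]1C(=O)N1CCC(NS(=O)(=O)c2cc(S(=O)(=O)c3ccccc3)ccc2C(F)(F)F)CC1` gives 25000 nM in a physicochemical assay for solubility (a higher number here means a more soluble compound, a lower number a less soluble compound), and stands lowest of the three numbers measured. Compound 2 `CCNC(=O)N1CCC[C@H]1C(=O)N1CCC(NS(=O)(=O)c2cc(S(=O)(=O)c3ccccc3)ccc2C(F)(F)F)CC1` gives 100000 nM in this assay, and compound 3 `CN1CCC[C@H]1C(=O)N1CCC(NS(=O)(=O)c2cc(S(=O)(=O)c3ccccc3)ccc2C(F)(F)F)CC1` gives 100000 nM. The steps away from compound 1 are a 4.0-fold higher number from compound 1 to compound 2 (0.60 log units; beyond the scatter) and a 4.0-fold higher number from compound 1 to compound 3 (0.60 log units; beyond the scatter); between the other two, no change at the digits printed from compound 2 to compound 3 (within the scatter). Compound 4 `O=C([C@@H]1CCCN1Cc1ccccc1)N1CCC(NS(=O)(=O)c2cc(S(=O)(=O)c3ccccc3)ccc2C(F)(F)F)CC1` differs from compound 1 by benzyl in place of tert-butoxycarbonyl on an amine nitrogen in a ring. Among the compounds with values here, both measured steps that remove the tert-butoxycarbonyl from this nitrogen gave a modest rise, so a rise of similar or smaller size is expected here; no measured step brings a benzyl or an aromatic ring to this place, which leaves the estimate wide. Compound 4 is therefore estimated at 40000 nM, with a range from 12000 nM to 130000 nM, which means an expected 1.6-fold higher number from compound 1 to compound 4 (0.20 log units; within the scatter).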

Compound 4, solubility: 25000 nM
Compound 4: the middle estimate sits 1.6-fold (0.20 log units) above what was measured, and the stated range covers the measured number.
By their numbers in this assay, from the lowest: compounds 1 and 4 (each within the scatter of the next); then compounds 2 and 3 (each within the scatter of the next).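

In this assay losing the tert-butoxycarbonyl from this ring nitrogen does not by itself raise the number: benzyl in its place gives (no change at the digits printed from compound 1 to compound 4 (within the scatter)). Benzyl also stands apart from the other two groups at this nitrogen (methyl: a 4.0-fold lower number from compound 3 to compound 4 (0.60 log units; beyond the scatter); ethylcarbamoyl: a 4.0-fold lower number from compound 2 to compound 4 (0.60 log units; beyond the scatter)), so the outcome here depends on the entering group as well as the leaving one. No supporting measurement accounts for this difference.

Open, going by these compounds, is whether an amine or a carboxylic acid on the benzyl ring would move compound 4 towards compound 3 in this assay. On these data alone, a pyridylmethyl group at this nitrogen is equally open.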